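A few compounds are considered here, and "the series" means these few. Any claim that something is new, unique, unknown or untested is made for them only; others in the source may bear on it.

Values in a functional assay on SK-MEL-28 cells (Homo sapiens) for cytotoxicity, read by CCK-8 assay, with a stated time of 24 h; on this read-out higher numbers stand for weaker inhibition and lower numbers for stronger inhibition:
- compound 1 `COc1ccccc1Oc1c(N)nc(Cc2ccccc2)nc1OCCO`: 14000 nM
- compound 2 `COc1ccccc1Oc1c(N)nc(-c2cccc(F)c2)nc1OCCO`: 3210 nM
- compound 3 `COc1ccccc1Oc1c(N)nc(-c2cccc(Cl)c2)nc1OCCO`: 4170 nM

Compound 3 stands within the scatter of compound 2, with a 1.3-fold higher number from compound 2 to compound 3 (0.11 log units; within the scatter). Both lie clearly lower than compound 1, with a 3.4-fold lower number from compound 1 to compound 3 (0.53 log units; beyond the scatter) and a 4.4-fold lower number from compound 1 to compound 2 (0.64 log units; beyond the scatter), modest steps made by replacing benzyl.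

Compound 4 `COc1ccccc1Oc1c(N)nc(-c2ccc(Cl)cc2)nc1OCCO` carries 4-chlorophenyl in place of 3-chlorophenyl on an aromatic carbon. Going by the values given here, no measured step moves the chloro group, so the evidence is indirect. The nearest change is the swap of chloro for fluoro, which stayed within the scatter. In this assay no step beyond the scatter is therefore expected, and the estimate is a 1.1-fold lower number from compound 3 to compound 4 (0.05 log units; within the scatter). For compound 4 the expected value is 3700 nM, with an estimated range of 1600 nM to 8500 nM.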

Compound 4, half-maximal inhibitory concentration: > 80000 nM
Compound 4: a limit, no number (the forecaster's own chance of this, stated with the estimate: 5%); at least 21-fold (1.33 log units) between middle value and limit.
By their numbers in this assay, from the lowest: compounds 2 and 3 (each within the scatter of the next); then compound 1. At a limit, above all of these: compound 4.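

In this assay, this position is sensitive to where the chloro group sits on the phenyl ring, a dependence the chloro-for-fluoro swap did not reveal: an at least 19-fold higher number from compound 3 to compound 4 (1.28 log units; beyond the scatter). The gap is similar against the 3-fluorophenyl compound, an at least 24-fold higher number from compound 2 to compound 4 (1.39 log units; beyond the scatter), and 4-chlorophenyl also does worse than benzyl, an at least 5.7-fold higher number from compound 1 to compound 4 (0.75 log units; beyond the scatter). Compound 4 stands only as a limit, not a number: the limit of > 80000 nM in this assay, at which 1 of the 4 values shown sits.

Open, as far as these compounds go, is whether 4-fluorophenyl or 4-methoxyphenyl at this position would also reach the limit. Also open, from the compounds shown here alone, is how an amine in place of the 2-hydroxyethoxy group would read.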